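This account rests on a few compounds, and the source may have more. Where it says the series, first, only, none or still open, it means among the compounds named here.

Three compounds sharing the core of compound 1 `Cc1ccc(C(=O)Nc2nnc(-c3ccc(O)c(O)c3)s2)cc1` have so far been tested in a functional assay on HeLa cells (Homo sapiens) for cytotoxicity, read by MTT assay, with a stated time of 72 h; a lower number here means a stronger inhibitor, a higher number a weaker inhibitor. Compound 1 gives 67100 nM. Compound 2 `O=C(COc1ccccc1)Nc1nnc(-c2ccc(O)c(O)c2)s1` gives 51300 nM in this assay, and compound 3 `O=C(Nc1nnc(-c2ccc(O)c(O)c2)s1)C1CCCCC1` gives 34500 nM. Compound 3 thus sits at the low end of the three numbers, but both a 1.9-fold lower number from compound 1 to compound 3 (0.29 log units; within the scatter) and a 1.5-fold lower number from compound 2 to compound 3 (0.17 log units; within the scatter) stay within the scatter, as does a 1.3-fold lower number from compound 1 to compound 2 (0.12 log units; within the scatter), so none of the three groups on the carbonyl carbon separates itself from the others.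

Compound 4 `O=C(Nc1nnc(-c2ccc(O)c(O)c2)s1)c1ccc(Cl)cc1` has not yet been measured. Its change from compound 3 is 4-chlorophenyl in place of cyclohexyl on a carbonyl carbon. Going by the values given here, the steps that bear on this change are those at the same carbonyl carbon. Compound 1 already carries an aromatic ring there, 4-methylphenyl, and a 1.9-fold lower number from compound 1 to compound 3 (0.29 log units; within the scatter) shows that exchanging it for cyclohexyl moved the number within the scatter only; a 1.5-fold lower number from compound 2 to compound 3 (0.17 log units; within the scatter) is of similar size. Returning from cyclohexyl to a six-membered aromatic ring, now 4-chlorophenyl, is therefore expected to produce no more than a step within the scatter, if anything toward a somewhat higher number as seen with compound 1. The estimated step is a 1.3-fold higher number from compound 3 to compound 4 (0.12 log units; within the scatter). Compound 4 is expected to give 45000 nM in this assay, with a range from 20000 nM to 100000 nM.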

Compound 4, half-maximal inhibitory concentration: 47300 nM
Estimate against measurement, compound 4: 1.1-fold (0.02 log units) below; the measured number falls inside the stated range.
By their numbers in this assay, from the lowest: compounds 3, 4, 2 and 1 (each within the scatter of the next).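

In this assay, the step of a 1.4-fold higher number from compound 3 to compound 4 (0.14 log units; within the scatter) shows that an aromatic ring carrying chloro can take the place of cyclohexyl on the carbonyl carbon without leaving the scatter, and the comparison with phenoxymethyl, a 1.1-fold lower number from compound 2 to compound 4 (0.04 log units; within the scatter), gives the same reading. The step of a 1.4-fold lower number from compound 1 to compound 4 (0.15 log units; within the scatter) adds the first change made on the aromatic ring itself, chloro in place of methyl on an aromatic carbon, and this too stays within the scatter. All four groups on the carbonyl carbon now lie within the scatter of one another, so this position has shown no difference among them, and nothing available explains that result.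

From the compounds shown here alone, whether a group of another kind on the carbonyl carbon, such as an amine, a carboxylic acid or a longer alkyl chain, would produce a step beyond the scatter remains open. Going by these compounds, the shared core is the same in all four compounds, so the effect of any change there also remains open, as does the question of whether these numbers reflect anything more specific than general cytotoxicity in this assay.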